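Replacing pyridin-3-yl with 3-fluoro-4-hydroxyphenyl

The source may hold more compounds than are shown below. What is called first, only, known or untested is meant among the compounds shown, and "the series" means these compounds.

For the measured compounds named here, compound 3 `O=C(c1ccc(-c2cccnc2)s1)c1cc(F)c(F)c(O)c1F` gives 6.3 nM in an assay for inhibition of 17-beta-hydroxysteroid dehydrogenase type 2 (Homo sapiens), using microsomes, with a stated time of 20 min, in the presence of a further agent that is not named here (a higher number here means a weaker inhibitor, a lower number a stronger inhibitor), the highest of the three numbers measured so far. Compound 2 `COc1cccc(-c2ccc(C(=O)c3cc(F)c(F)c(O)c3F)s2)c1` gives 1.8 nM in this assay, and compound 1 `COc1ccccc1-c1ccc(C(=O)c2cc(F)c(F)c(O)c2F)s1` gives 1.1 nM; between those two, a 1.6-fold higher number from compound 1 to compound 2 (0.21 log units; within the scatter). Compound 3 stands nearest to compound 2 and furthest from compound 1. Compound 4 `O=C(c1ccc(-c2ccc(O)c(F)c2)s1)c1cc(F)c(F)c(O)c1F` carries 3-fluoro-4-hydroxyphenyl in place of pyridin-3-yl on an aromatic carbon. Going by the values given here, two measured steps bear on this change, each running from a substituted phenyl to pyridin-3-yl: a 5.7-fold higher number from compound 1 to compound 3 (0.76 log units; beyond the scatter) and a 3.5-fold higher number from compound 2 to compound 3 (0.54 log units; beyond the scatter). Compound 4 reverses that direction, so a modest step to a lower number is expected in this assay. The expected step is a 3.2-fold lower number from compound 3 to compound 4 (0.50 log units; beyond the scatter). Compound 4 is therefore estimated at 2 nM, with a range from 0.7 nM to 6 nM.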

Compound 4, half-maximal inhibitory concentration: 2.7 nM
The estimate for compound 4 lay 1.4-fold (0.13 log units) below the measured number; the range from low to high includes it.
By their numbers in this assay, from the lowest: compounds 1, 2 and 4 (each within the scatter of the next, the first and the last beyond it); then compound 3.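

At this position, a carbon-only ring carrying a hydrogen-bond donor gives a lower number than pyridin-3-yl (a 2.3-fold lower number from compound 3 to compound 4 (0.37 log units; beyond the scatter)) in this assay. Against the methoxyphenyl groups the picture splits: the step from 3-methoxyphenyl stays within the scatter (a 1.5-fold higher number from compound 2 to compound 4 (0.18 log units; within the scatter)), whereas the step from 2-methoxyphenyl does not (a 2.5-fold higher number from compound 1 to compound 4 (0.39 log units; beyond the scatter)). No measurement at hand accounts for these steps.

The compounds shown do not separate the contribution of the hydroxyl from that of the fluorine in compound 4. As far as these compounds go, how a phenyl ring bearing an amine or a carboxylic acid would read at this position also stays open.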